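Swapping the dichlorophenyl group of compound 2 for indole

The source may hold more compounds than are shown below. What is called first, only, known or untested is meant among the compounds shown, and "the series" means these compounds.

In a functional assay on SMMC-7721 cells (Homo sapiens) for cytotoxicity, read by MTT assay, with a stated time of 72 h (on this read-out higher numbers stand for weaker inhibition and lower numbers for stronger inhibition), compound 1 `COc1cccc(C=C2C(=O)N(c3ccc(Cl)cc3)N(c3ccc(Cl)cc3)C2=O)c1O` gives 64900 nM. Compound 2 `O=C1C(=Cc2ccc(Cl)cc2Cl)C(=O)N(c2ccc(Cl)cc2)N1c1ccc(Cl)cc1` gives only a limit of the assay, > 128000 nM, so no number is known for it. Its place on the scale is the limit of > 128000 nM in this assay, at which 1 of the 2 values shown sits.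

The next compound, compound 3 `O=C1C(=Cc2c[nH]c3ccccc23)C(=O)N(c2ccc(Cl)cc2)N1c1ccc(Cl)cc1`, differs from compound 2 at a single place: 1H-indol-3-yl in place of 2,4-dichlorophenyl on a double-bonded chain carbon bound to a double-bonded ring carbon. The group 1H-indol-3-yl stands in place of 2,4-dichlorophenyl on a double-bonded chain carbon bound to a double-bonded ring carbon.

Among the compounds with values here, only one measured step bears on this place, and it is an at least 1.9-fold higher number from compound 1 to compound 2 (0.29 log units; that floor lies within the scatter). In that step, 2,4-dichlorophenyl took the place of 2-hydroxy-3-methoxyphenyl. This step gives a floor and no true size, so it sets only a loose guide for the change now in question. Within the data shown here, compound 1, at 64900 nM, supplies the one true number with the shared core, and compound 3 is expected to fall near it. A further limit of the assay remains possible for compound 3.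

The expected change is an at least 2.1-fold lower number from compound 2 to compound 3 (0.32 log units; beyond the scatter), towards a lower number and stronger inhibition. For compound 3 the estimate is 60000 nM, with an expected range from 20000 nM to 128000 nM.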

Compound 3, half-maximal inhibitory concentration: 19600 nM
For compound 3 the middle estimate is 3.1-fold (0.49 log units) above the measured one, and the stated range ends above it.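

In this assay this place now shows a change with a true size at both ends: 1H-indol-3-yl in place of 2-hydroxy-3-methoxyphenyl gives a 3.3-fold lower number from compound 1 to compound 3 (0.52 log units; beyond the scatter), a step beyond the scatter between two real numbers. Set against 2,4-dichlorophenyl, the same group gives an at least 6.5-fold lower number from compound 2 to compound 3 (0.81 log units; beyond the scatter), so the place on a double-bonded chain carbon bound to a double-bonded ring carbon now has a step whose floor also lies beyond the scatter, and compound 3 is the strongest of the three compounds. That second step remains only a floor because compound 2 stands at a limit of the assay and not at a number: the limit of > 128000 nM in this assay, at which 1 of the 3 values shown sits.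

The compounds shown leave open whether the gain follows the hydrogen on the indole nitrogen, which 1-methyl-1H-indol-3-yl would lack, or the two fused rings, which a naphthyl group would keep without any nitrogen. They also leave open whether the indole would give a step of the same size if the two chlorine atoms on the shared core were replaced by methoxy groups.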